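This account rests on a few compounds, and the source may have more. Where it says the series, first, only, none or still open, it means among the compounds named here.

Compound 1 `COc1cc(C(=O)c2cn(-c3cccc(N)c3)cc2-c2ccccc2Cl)cc(OC)c1OC` gives 40 nM
Compound 2 `COc1cc(C(=O)c2cn(-c3cccc(N)c3)cc2-c2ccccc2[N+](=O)[O-])cc(OC)c1OC` gives 14 nM
Compound 3 `COc1cc(C(=O)c2cn(-c3cccc(N)c3)cc2-c2ccc([N+](=O)[O-])cc2)cc(OC)c1OC` gives 110 nM

In a functional assay on MCF7 cells (Homo sapiens) for cytotoxicity, read by MTT assay, with a stated time of 96 h (a lower number here means a stronger inhibitor, a higher number a weaker inhibitor), compound 3 has the highest of these numbers (110 nM), making it the weakest inhibitor of the three. Among the measured compounds shown here, compound 4 `COc1cc(C(=O)c2cn(-c3cccc(N)c3)cc2-c2cccc(N)c2)cc(OC)c1OC` carries 3-aminophenyl in place of 4-nitrophenyl on an aromatic carbon and no measured compound has that group there, so the evidence is indirect. Both measured steps that end at 4-nitrophenyl raised the number (a 2.8-fold higher number from compound 1 to compound 3 (0.44 log units; beyond the scatter) and a 7.9-fold higher number from compound 2 to compound 3 (0.90 log units; beyond the scatter)). Removing that group is therefore expected to lower the number modestly, and the estimated change is similar in size to the first of those steps (a 2.8-fold lower number from compound 3 to compound 4 (0.44 log units; beyond the scatter)). The estimate for compound 4 is 40 nM with an expected range from 10 nM to 160 nM as its upper end.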

Compound 4, half-maximal inhibitory concentration: 60 nM
Estimate against measurement, compound 4: 1.5-fold (0.18 log units) below, within the range that was stated.
By their numbers in this assay, from the lowest: compound 2; then compounds 1, 4 and 3 (each within the scatter of the next, the first and the last beyond it).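

In this assay this position accepts 3-aminophenyl with little change, since a 1.8-fold lower number from compound 3 to compound 4 (0.26 log units; within the scatter) and a 1.5-fold higher number from compound 1 to compound 4 (0.18 log units; within the scatter) both stay within the scatter. Only 2-nitrophenyl stands apart, with a 4.3-fold higher number from compound 2 to compound 4 (0.63 log units; beyond the scatter) and compound 2 holding the lowest number of the four. Nothing available explains these differences.

Compound 3 and compound 4 differ in both the ring's substituent and where it sits, so those two changes remain unseparated. Going by these compounds, how a plain phenyl or a pyridine ring would compare at this place also stays open.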